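A few compounds are considered here, and "the series" means these few. Any claim that something is new, unique, unknown or untested is made for them only; others in the source may bear on it.

Compound 1, `COC(=O)CCCCCOc1cc(-c2ccccc2)cc(-c2ccccc2)n1`: 40 nM
Compound 2, `O=C(O)CCCCCOc1cc(-c2ccccc2Cl)cc(-c2ccccc2)n1`: 200 nM
Compound 3, `COc1ccc(-c2cc(-c3ccccc3)cc(OCCCCCC(=O)O)n2)cc1`: 1000 nM

All three compounds were tested in an assay on cell membranes from spleen (Cavia porcellus) for binding affinity to leukotriene B4 receptor 1 (Homo sapiens); on this read-out lower numbers stand for stronger inhibition and higher numbers for weaker inhibition. In this assay compound 1 gives 40 nM, the lowest of the three numbers. Compound 2 gives 200 nM, a higher number that lies beyond the usual scatter, and compound 3 gives 1000 nM, higher still. Among the measured compounds shown here, compounds 2 and 3 each differ from compound 1 in more than one place, so none of these pairs isolates a single structural change, and no step between measured compounds can be read off.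

Compound 4, `NC(=O)CCCCCOc1cc(-c2ccccc2)cc(-c2ccccc2)n1`, differs from compound 1 in exactly one place: amino in place of methoxy on a carbonyl carbon. For the measured compounds named here, no measured pair shows this change, so the expectation rests on compound 1 alone and on the fact that the rest of the molecule is kept. The expected step is a 1.5-fold higher number from compound 1 to compound 4 (0.18 log units; within the scatter), a modest rise in the number that would not clearly stand out from the scatter. Compound 4 is therefore estimated at 60 nM, with a likely range from 20 nM to 200 nM.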

Compound 4, half-maximal inhibitory concentration: 160 nM
Compound 4: middle estimate off by 2.7-fold (0.43 log units), on the low side; the measured number falls inside the stated range.
By their numbers in this assay, from the lowest: compound 1; then compounds 4 and 2 (each within the scatter of the next); then compound 3.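

Replacing methoxy with amino on the carbonyl carbon, which turns the methoxycarbonyl end of the chain into carbamoyl, gives in this assay a 4.0-fold higher number from compound 1 to compound 4 (0.60 log units; beyond the scatter). Among the compounds shown here, this is the first comparison here that changes only one place, and it shows that the read-out responds to what sits on this carbonyl carbon, even though the chain and the rest of the core stay the same. No measurement shown here explains the shift.

Going by these compounds, how a carboxylic acid or an N-methylcarbamoyl group would compare at this place on the core of compound 1 remains open. Compound 2 and compound 3 both end in a carboxylic acid, but each differs from compound 1 in more than one place, so neither can settle that question.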